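The compounds below may be only part of what the source reports. "The series", "measured", "known", "first", "only" and "open" are said of these compounds alone.

Working notes on the series. Compound 1 `Cc1cc(O)c(C2=NN(c3ccc(S(N)(=O)=O)cc3)C(c3ccccc3O)C2)cc1Cl` gives 8120 nM in a functional assay on OVCAR-5 cells (Homo sapiens) for antiproliferative activity, with a stated time of 48 h; a higher number here means that more compound is tolerated, a lower number that less compound is tolerated. Compound 2 `Cc1cc(O)c(C2=NN(c3ccc(S(N)(=O)=O)cc3)C(c3ccccc3Cl)C2)cc1Cl` gives 6230 nM in this assay. Compound 3 `COc1ccc(C2CC(c3cc(Cl)c(C)cc3O)=NN2c2ccc(S(N)(=O)=O)cc2)cc1OC` gives 27800 nM in this assay. Among these three numbers compound 3 stands highest: the steps of a 3.4-fold higher number from compound 1 to compound 3 (0.53 log units; beyond the scatter) and a 4.5-fold higher number from compound 2 to compound 3 (0.65 log units; beyond the scatter) both lie beyond the scatter, whereas a 1.3-fold lower number from compound 1 to compound 2 (0.12 log units; within the scatter) does not.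

Compound 4 `COc1ccc(C2CC(c3cc(Cl)c(C)cc3O)=NN2c2ccc(S(N)(=O)=O)cc2)c(OC)c1OC` has not yet been measured in this assay. Its difference from compound 3 is methoxy in place of hydrogen on an aromatic carbon. For the measured compounds named here, none of the measured steps adds a methoxy to an aromatic carbon; the two steps that move the number beyond the scatter each exchange the whole aryl group on the saturated ring carbon, and they bear on the present step only in that they place the 3,4-dimethoxyphenyl compound at the high end of the series. The present change adds two heavy atoms to that same aryl group rather than replacing it. The step in this assay is therefore expected to be small, with no direction beyond the scatter expected. Compound 4 is estimated at 32000 nM, with a range from 11000 nM to 95000 nM, which is expected to correspond to a step of a 1.2-fold higher number from compound 3 to compound 4 (0.06 log units; within the scatter).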

Compound 4, concentration lethal to 50% of the cells: 9790 nM
Estimate against measurement, compound 4: 3.3-fold (0.51 log units) above; measured number outside the range, below it.
By their numbers in this assay, from the lowest: compounds 2, 1 and 4 (each within the scatter of the next); then compound 3.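

For the compounds shown here, the methoxy group entering on the 3,4-dimethoxyphenyl ring, ortho to a large group and ortho to a methoxy group, is the first change that adds to this aryl group rather than exchanging it, and in this assay it does move the number: a 2.8-fold lower number from compound 3 to compound 4 (0.45 log units; beyond the scatter). Once the group is 2,3,4-trimethoxyphenyl, exchanging it for the aryl groups of the earlier compounds no longer gives a step beyond the scatter: a 1.6-fold higher number from compound 2 to compound 4 (0.20 log units; within the scatter) and a 1.2-fold higher number from compound 1 to compound 4 (0.08 log units; within the scatter). The high number of compound 3 therefore goes with the 3,4-dimethoxyphenyl pattern in particular and not with methoxy groups on this aryl ring in general, and no measurement at hand accounts for the shift.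

The compounds shown cannot separate the place of the added methoxy from the count of methoxy groups, a question that a 2,4-dimethoxyphenyl or 2,3-dimethoxyphenyl compound would address. Also open, as far as these compounds go, is whether another group at this same place, such as an ethoxy, an amine or a carboxylic acid, would give a step like that of methoxy.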